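The source may hold more compounds than are shown below. What is called first, only, known or untested is meant among the compounds shown, and "the series" means these compounds.

Compound 1 `CCCCOc1ccc(C(=O)NNc2c(Br)cccc2Br)cc1`: > 100000 nM (a limit, not a number)
Compound 2 `N#Cc1ccc(C(=O)NNc2c(Br)cccc2Br)cc1`: > 100000 nM (a limit, not a number)
Compound 3 `COC(=O)c1ccc(C(=O)NNc2c(Br)cccc2Br)cc1`: 87600 nM

All three values come from a toxicity assay on MDCK cells (Canis lupus familiaris) for cytotoxicity, read by CCK-8 assay, with a stated time of 48 h; a higher number here means that more compound is tolerated, a lower number that less compound is tolerated. Compound 3 is the only one of the three with an actual number, 87600 nM. The other two compounds rest at the limit of > 100000 nM in this assay, at which 2 of the 3 values shown sit.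

Compound 4 `O=C(NNc1c(Br)cccc1Br)c1ccc(F)cc1` keeps the shared core but carries fluoro in place of methoxycarbonyl on an aromatic carbon.

Among the compounds with values here, two measured steps bear on this change, since each swaps the group at that same aromatic carbon and ends in compound 3: an at least 1.1-fold lower number from compound 1 to compound 3 (0.05 log units; that floor lies within the scatter), and an at least 1.1-fold lower number from compound 2 to compound 3 (0.05 log units; that floor lies within the scatter). The third, a step that the two limits leave unreadable from compound 1 to compound 2, gives no size to work with. Neither of the two readable steps goes beyond the scatter, so no clear change is expected in this assay here. The expected result is a 1.1-fold higher number from compound 3 to compound 4 (0.06 log units; within the scatter), which would stay within the scatter, with any drift towards a higher number. Compound 4 may well report only a limit as well. For compound 4 the estimate is 100000 nM, with an expected range from 55000 nM to 180000 nM.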

Compound 4, half-maximal cytotoxic concentration: > 100000 nM
Compound 4: no number, only a limit; the forecaster's own chance of this, stated with the estimate: 60%; the middle value sits exactly at the limit.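

Fluoro at this aromatic carbon, para to a large group, gives no number either: in this assay compound 4 gives > 100000 nM, which is a limit of the assay. As far as these compounds go, replacing methoxycarbonyl with this single atom gives an at least 1.1-fold higher number from compound 3 to compound 4 (0.05 log units; that floor lies within the scatter), so even a much smaller group, with no hydrogen-bond acceptors counted, shows no clear change, although the true size of the step stays unknown. The steps to compound 4 from compound 1 and compound 2 cannot be read, and the values now gather at one limit: the limit of > 100000 nM in this assay, at which 3 of the 4 values shown sit.

From the compounds shown here alone, how far compound 1, compound 2 and compound 4 truly lie from one another remains open. Going by these compounds, it also remains open whether an amine or a carboxylic acid at this carbon would move the value clearly beyond the scatter.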